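Half-life notes: from compound 1 to compound 3

The source may report more compounds than this note shows. Statements on the series, on what has been measured and on what is new or still open speak of the compounds shown alone.

Measured in a physicochemical assay for metabolic stability, read by HPLC, in phosphate buffer, at 37 degrees C, at pH 7.4; on this read-out lower numbers stand for a shorter-lived compound and higher numbers for a longer-lived compound:
- compound 1 `CCCC(CCC)C(=O)OC[C@H]1O[C@@H](n2cnc3c(N)ncnc32)[C@H](OC(=O)C(CCC)CCC)[C@]1(C)O`: > 72 h
- compound 2 `CCCC(CCC)C(=O)O[C@H]1[C@H](n2cnc3c(N)ncnc32)O[C@H](CO)[C@@]1(C)O`: > 72 h

Compound 1 gives > 72 h, which is a limit of the assay and not a number. Compound 2 gives > 72 h, which is also a limit. Going by the values given here, the series so far therefore offers only (the limit of > 72 h in this assay, at which 2 of the 2 values shown sit), and compound 1 has no exact standing within it.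

Compound 3 `CCCC(CCC)C(=O)OC[C@H]1O[C@@H](n2cnc3c(N)ncnc32)[C@H](O)[C@]1(C)O` has not been measured. It differs from compound 1 as follows: hydrogen in place of (1-propylbutyl)carbonyl on an oxygen on a saturated carbon. The same difference reads ((1-propylbutyl)carbonyl)oxy to hydroxy.

Among the compounds with values here, the one measured step that bears on this is a step that the two limits leave unreadable from compound 1 to compound 2, where the same replacement falls on the other oxygen that carries a (1-propylbutyl)carbonyl in compound 1. Its size cannot be read, but it gives no sign of a shorter life, since compound 2 still reports > 72 h.

No shift in either direction beyond the scatter is therefore expected in this assay, and the estimated change is a step that the limit leaves unreadable from compound 1 to compound 3. Compound 3 is expected near 100 h, with an estimated range of 72 h to 200 h.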

Compound 3, half-life: > 72 h
Compound 3: no number, only a limit; the forecaster's own chance of this, stated with the estimate: 80%; the middle value does not contradict the limit.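

In this assay compound 3 gives > 72 h, which is a limit and not a number. No step among compound 1, compound 2 and compound 3 can be read, and the series offers only this: the limit of > 72 h in this assay, at which 3 of the 3 values shown sit.

The compounds shown leave open how long each actually lasts, and whether hydroxy in place of ((1-propylbutyl)carbonyl)oxy changes the half-life at all.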